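Hydrazone series: pyridin-3-yl in place of 4-methoxyphenyl

A few compounds are considered here, and "the series" means these few. Any claim that something is new, unique, unknown or untested is made for them only; others in the source may bear on it.

Measured so far:
Compound 1 `O=C(N/N=C/c1ccc(F)cc1)c1cccnc1Nc1cccc(C(F)(F)F)c1` gives 36.5% in a functional assay on the whole organism (strain Wistar) for inhibition, with Rattus norvegicus as the target, read by paw edema, with a stated time of 4 h, at a dose of 10 mg/kg by the intraperitoneal route; a lower number here means less inhibition, a higher number more inhibition at the dose given (going by the name of the read-out).
Compound 2 `COc1ccc(/C=N/NC(=O)c2cccnc2Nc2cccc(C(F)(F)F)c2)cc1` gives 14% in this assay.

Within the data shown here, compound 2 stands lowest of the two numbers in this assay; compound 1 is its nearest neighbour and the only step in hand is a number 22.5 percentage points lower from compound 1 to compound 2 (beyond the scatter). Compound 3 `O=C(N/N=C/c1cccnc1)c1cccnc1Nc1cccc(C(F)(F)F)c1` differs from compound 2 by pyridin-3-yl in place of 4-methoxyphenyl on a carbon with a double bond to nitrogen. Among the measured compounds shown here, no measured step bears directly on this change; the one earlier step shows only that exchanging the group on the carbon with a double bond to nitrogen moved the read-out by a modest amount. For compound 3 a modest upward step is expected, a number 11 percentage points higher from compound 2 to compound 3 (beyond the scatter). Compound 3 is estimated at 25%, between 8% and 45%.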

Compound 3, a percentage reported as inhibition, in the whole organism at one dose (the size of the read-out at that dose, not a potency): 36%
Compound 3: the middle estimate sits 11 percentage points below what was measured; measured number inside the range.
By their numbers in this assay, from the lowest: compound 2; then compounds 3 and 1 (each within the scatter of the next).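

In this assay pyridin-3-yl gives a number 22 percentage points higher from compound 2 to compound 3 (beyond the scatter) on the carbon with a double bond to nitrogen, so the earlier drop with 4-methoxyphenyl is not seen with this second replacement. With a number 0.5 percentage points lower from compound 1 to compound 3 (within the scatter) pyridin-3-yl and 4-fluorophenyl cannot be told apart here, and among these three groups only 4-methoxyphenyl stands apart. Nothing available explains this difference.

From the compounds shown here alone, whether an unsubstituted phenyl or a 4-aminophenyl at this position would sit with compound 2 or with compounds 1 and 3 remains open. Also open, going by these compounds, is whether this order would hold at other doses or read-out times.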